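This account rests on a few compounds, and the source may have more. Where it says the series, first, only, none or still open, it means among the compounds named here.

Measured so far in a functional assay on K562 cells (Homo sapiens) for inhibition, read by trypan blue exclusion, with a stated time of 72 h; on this read-out higher numbers stand for weaker inhibition and lower numbers for stronger inhibition:
compound 1 `Cn1c(=O)c(S(=O)(=O)c2ccccc2)cc2cnc(Nc3ccc4cc[nH]c4c3)nc21` — 10000 nM
compound 2 `Cn1c(=O)c(S(=O)(=O)c2ccc(F)cc2)cc2cnc(Nc3cnc4[nH]ccc4c3)nc21` — 750 nM
compound 3 `Cn1c(=O)c(S(=O)(=O)c2ccc(F)cc2)cc2cnc(Nc3ccc4[nH]ncc4c3)nc21` — 10000 nM

Going by the values given here, compound 2 holds the lowest number of the three; compound 1 and compound 3 both sit well higher, and the one comparable single-point step is a 13-fold higher number from compound 2 to compound 3 (1.12 log units; beyond the scatter), which concerns the aromatic amine and not the sulfonyl aryl.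

Compound 4 `Cn1c(=O)c(S(=O)(=O)c2ccccc2)cc2cnc(Nc3cnc4[nH]ccc4c3)nc21` differs from compound 2 by hydrogen in place of fluoro on an aromatic carbon. Among the compounds with values here, no measured pair isolates this change: compound 1 and compound 2 differ at both the sulfonyl aryl and the amine, so their values cannot be split. With nothing bearing on the fluoro, no step beyond the scatter is expected in this assay.

Compound 4 is therefore estimated at 1000 nM, range 350 nM to 3500 nM, meaning an expected step of a 1.3-fold higher number from compound 2 to compound 4 (0.12 log units; within the scatter).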

Compound 4, half-maximal inhibitory concentration: 5000 nM
For compound 4 the middle estimate is 5.0-fold (0.70 log units) below the measured one, outside the stated range (above it).
By their numbers in this assay, from the lowest: compound 2; then compounds 4, 1 and 3 (each within the scatter of the next).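

In this assay the change from 4-fluorophenyl to phenyl is now isolated, and the step (a 6.7-fold higher number from compound 2 to compound 4 (0.82 log units; beyond the scatter)) shows that the fluoro on this aromatic carbon counts in this series with the amine of compound 2. With phenylsulfonyl kept, the change of amine gives a step (a 2.0-fold lower number from compound 1 to compound 4 (0.30 log units; within the scatter)) that does not separate the two compounds. No evidence on the origin of the fluoro step is at hand.

Going by these compounds, whether chloro, methoxy or an amine on this aromatic carbon would match fluoro stays open. So does whether the fluoro step holds with other amines on the shared core.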